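A few compounds are considered here, and "the series" means these few. Any claim that something is new, unique, unknown or untested is made for them only; others in the source may bear on it.

In an ADME assay on THP-1 cells (Homo sapiens) for cytotoxicity, read by flow cytometry and propidium iodide staining, with a stated time of 72 h (on this read-out lower numbers stand for stronger inhibition and higher numbers for weaker inhibition), compound 1 `CC(=O)Nc1ccc2oc(-c3ccccc3)cc(=O)c2c1` gives 97000 nM. Going by the values given here, its only measured neighbour is compound 2 `CC(=O)Nc1ccc2oc(-c3cccc(C(F)(F)F)c3)cc(=O)c2c1` at 50000 nM, so the two values lie within the scatter of each other and compound 1 has no clear rank yet. Compound 3 `CC(=O)Nc1ccc2oc(-c3ccccc3)c(O)c(=O)c2c1` keeps the core of compound 1 and carries hydroxy in place of hydrogen on an aromatic carbon, ortho to a phenyl group. The series holds no measured hydroxy change. Among the compounds with values here, the one measured step, a 1.9-fold lower number from compound 1 to compound 2 (0.29 log units; within the scatter), is a different change, trifluoromethyl in place of hydrogen on an aromatic carbon, and it offers only weak guidance. It gives no ground for expecting a shift in either direction beyond the scatter. The expected change is a 1.4-fold lower number from compound 1 to compound 3 (0.14 log units; within the scatter), which is no clear step. The estimated value for compound 3 is 70000 nM, with an expected range of 25000 nM to 200000 nM.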

Compound 3, half-maximal inhibitory concentration: 36000 nM
The estimate for compound 3 lay 1.9-fold (0.29 log units) above the measured number; measured number inside the range.
By their numbers in this assay, from the lowest: compounds 3, 2 and 1 (each within the scatter of the next, the first and the last beyond it).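

Hydroxy in place of hydrogen on this aromatic carbon, ortho to a phenyl group and two atoms from the ring oxygen, gives the first step in the series that lies beyond the scatter in this assay: a 2.7-fold lower number from compound 1 to compound 3 (0.43 log units; beyond the scatter), modest in size, with compound 3 still at 36000 nM. The only earlier step, the trifluoromethyl change, a 1.9-fold lower number from compound 1 to compound 2 (0.29 log units; within the scatter), did not separate from the scatter, so this position is the first shown to shift the number at all. No measurement on hand accounts for the shift.

As far as these compounds go, whether the step belongs to hydroxy itself or to any group on this carbon stays open; methoxy or a fluorine atom at the same place would separate the two. Also open, from the compounds shown here alone, is whether hydroxy gives a similar step on the core of compound 2.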